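Hydroxamic Amide in Place of a Branched Amide

The source may report more compounds than this note shows. Statements on the series, on what has been measured and on what is new or still open speak of the compounds shown alone.

Compound 1 `CC(C)CCn1nc(-c2cccs2)c(O)c(C2=NS(=O)(=O)c3ccccc3N2)c1=O` gives 0.2 h in an in vitro ADME assay on microsomes from liver (Homo sapiens) for metabolic stability, tested at 5 uM; on this read-out higher numbers stand for a longer-lived compound and lower numbers for a shorter-lived compound. Compound 2 `CC(C)CCn1nc(-c2cccs2)c(O)c(C2=NS(=O)(=O)c3cc(OCC(N)=O)ccc3N2)c1=O` gives 0.383 h in this assay, and compound 3 `CCC(Oc1ccc2c(c1)S(=O)(=O)N=C(c1c(O)c(-c3cccs3)nn(CCC(C)C)c1=O)N2)C(N)=O` gives 0.35 h, the second highest of the three numbers, lying within the scatter of both others. Compound 4 `CC(C)CCn1nc(-c2cccs2)c(O)c(C2=NS(=O)(=O)c3cc(OCC(=O)NO)ccc3N2)c1=O` differs from compound 3 in one place: (hydroxycarbamoyl)methyl in place of 1-carbamoylpropyl on an oxygen on an aromatic ring. The measured steps that touch this region are all small: a 1.9-fold higher number from compound 1 to compound 2 (0.28 log units; within the scatter), a 1.8-fold higher number from compound 1 to compound 3 (0.24 log units; within the scatter), and a 1.1-fold lower number from compound 2 to compound 3 (0.04 log units; within the scatter). For the measured compounds named here, no measured step covers a hydroxycarbamoyl group, so nothing beyond the scatter is expected from this change. Compound 4 is therefore estimated at 0.35 h, with a range from 0.15 h to 0.8 h, which corresponds to an expected step of no change at the digits printed from compound 3 to compound 4 (within the scatter).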

Compound 4, half-life: > 1 h
Compound 4 ended at the assay's limit; the forecaster's own chance of this, stated with the estimate: 5%; middle value at least 2.8-fold (0.45 log units) away from the limit.
By their numbers in this assay, from the lowest: compounds 1, 3 and 2 (each within the scatter of the next). At a limit, above all of these: compound 4.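

Compound 4 stands at a limit, not at a number: the limit of > 1 h in this assay, at which 1 of the 4 values shown sits. Hydroxy in place of hydrogen on an amide-type nitrogen gives an at least 2.6-fold higher number from compound 2 to compound 4 (0.41 log units; beyond the scatter), so this one change at the end of the side chain moves the half-life beyond the scatter. Likewise, the exchange of side chains gives an at least 2.8-fold higher number from compound 3 to compound 4 (0.45 log units; beyond the scatter), and (hydroxycarbamoyl)methoxy in place of hydrogen gives an at least 5.0-fold higher number from compound 1 to compound 4 (0.69 log units; beyond the scatter), whereas the carbamoylmethoxy and 1-carbamoylpropoxy groups stayed within the scatter of compound 1.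

Going by these compounds, how far compound 4 lies past the limit remains open. The compounds shown also leave open whether a methoxy on that nitrogen, or a carboxylic acid in place of the hydroxycarbamoyl group, would give the same result.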